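The source may report more compounds than this note shows. Statements on the series, on what has been measured and on what is new or still open speak of the compounds shown alone.

In an in vitro ADME assay on microsomes from liver (Homo sapiens) for pharmacokinetics, read by LC-MS (a lower number here means slower removal, a higher number faster removal of the compound), compound 3 (`Cc1nc2cc(OC(F)(F)F)ccc2n1-c1ccc(C(=O)NC2CC2)s1`) gives 7 mL/min/kg, within the scatter of compound 1 (`Cc1ccc2c(c1)nc(C)n2-c1ccc(C(=O)NC2CC2)s1`) at 8 mL/min/kg and of compound 2 (`Cc1ccc2nc(C)n(-c3ccc(C(=O)NC4CC4)s3)c2c1`) at 10 mL/min/kg. The next structure, compound 4 (`Cc1nc2cc(C(F)(F)F)ccc2n1-c1ccc(C(=O)NC2CC2)s1`), carries trifluoromethyl in place of trifluoromethoxy on an aromatic carbon. Among the compounds with values here, one measured step bears on this change: a 1.1-fold lower number from compound 1 to compound 3 (0.06 log units; within the scatter), with trifluoromethoxy in place of methyl on an aromatic carbon. That step stays within the scatter, and no measured change of this group yet goes beyond it. No step beyond the scatter is therefore expected in this assay, and the expected 1.1-fold higher number from compound 3 to compound 4 (0.06 log units; within the scatter) is small. For compound 4 the estimated value is 8 mL/min/kg, with an expected range of 5 mL/min/kg to 13 mL/min/kg.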

Compound 4, clearance: 4 mL/min/kg
Estimate against measurement, compound 4: 2.0-fold (0.30 log units) above; measured number outside the range, below it.
By their numbers in this assay, from the lowest: compounds 4, 3, 1 and 2 (each within the scatter of the next, the first and the last beyond it).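

In this assay, replacing the oxygen-linked group at this aromatic carbon gives a 1.8-fold lower number from compound 3 to compound 4 (0.24 log units; within the scatter) and, against the original methyl, a 2.0-fold lower number from compound 1 to compound 4 (0.30 log units; within the scatter). Both steps remain within the scatter, so methyl, trifluoromethoxy and trifluoromethyl are not separated at this position. The change of trifluoromethoxy to trifluoromethyl, which removes the oxygen, therefore shows no clear effect on clearance here. As far as these compounds go, whether an amine, a carboxylic acid or a longer chain at this carbon would stay within the same range remains open. Nothing available explains these numbers.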